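This account rests on a few compounds, and the source may have more. Where it says the series, first, only, none or still open, it means among the compounds named here.

Compound 1 `Nc1cc(N)c2nc(-c3ccccc3)c(NCc3ccc(Cl)c(Cl)c3)nc2c1` is one of three compounds examined in a functional assay on M14 cells (Homo sapiens) for inhibition, read by sulforhodamine B assay, with a stated time of 48 h; a lower number here means that less compound is tolerated, a higher number that more compound is tolerated. Among the compounds with values here, compound 1 gives 75900 nM, the only outright number among the three. Compound 2 `CCOC(=O)[C@H](CCC(=O)O)NC(=O)c1ccc(Sc2nc3cc(N)cc(N)c3nc2-c2ccccc2)cc1` reaches only a limit of the assay, < 100000 nM. Compound 3 `Nc1cc(N)c2nc(-c3ccccc3)c(Sc3ccc(Cl)c(Cl)c3)nc2c1` likewise reaches only a limit, < 100000 nM. So compound 1 stands as the single measured number, while the other two sit at the limit of < 100000 nM in this assay, at which 2 of the 3 values shown sit, and no comparison between two measured numbers can be drawn from what is shown.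

Compound 4 `COc1ccc(CNc2nc3cc(N)cc(N)c3nc2-c2ccccc2)cc1OC` has not yet been measured. It differs from compound 1 in one place: 3,4-dimethoxyphenyl in place of 3,4-dichlorophenyl on a saturated chain carbon bound to a nitrogen on an aromatic ring. Within the data shown here, no measured step of this kind exists among the three compounds, so the size of the change can only be estimated. With nothing in the shown values pointing to a shift in either direction, the expected step from compound 1 to compound 4 is none beyond the scatter, a 1.1-fold higher number from compound 1 to compound 4 (0.02 log units; within the scatter). Compound 4 is therefore expected to give 80000 nM, with a likely range from 30000 nM to 150000 nM.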

Compound 4, concentration lethal to 50% of the cells: 33900 nM
The estimate for compound 4 lay 2.4-fold (0.37 log units) above the measured number; the measured number falls inside the stated range.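

Within the data shown here, this is the first step that can be read in the set: replacing 3,4-dichlorophenyl with 3,4-dimethoxyphenyl on a saturated chain carbon bound to a nitrogen on an aromatic ring gives a 2.2-fold lower number from compound 1 to compound 4 (0.35 log units; beyond the scatter) in this assay. The group at this place therefore affects the read-out, although the change is modest, and less of the dimethoxy compound is tolerated by the cells. Compound 2 and compound 3 each stand at a limit of the assay rather than a number, so no step to either can be read: the limit of < 100000 nM in this assay, at which 2 of the 4 values shown sit.

This single swap changes the two chlorine atoms to two methoxy groups, and it cannot show which difference between them matters. An unsubstituted phenyl or a 3,4-dimethylphenyl at this place would help separate the role of the oxygen atoms from that of the added atoms.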